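This account rests on a few compounds, and the source may have more. Where it says the series, first, only, none or still open, it means among the compounds named here.

Working notes on a small set of amides sharing a methylated anilide core.

Compound 1 `Cc1cccc(N(C)C(=O)c2ccc(Oc3ccccc3C)cc2)c1` carries a 2-methylphenoxy group on the aryl side of the carbonyl. In an assay for inhibition of 17-beta-hydroxysteroid dehydrogenase type 1 (Homo sapiens), read by HPLC, with a stated time of 10 min (a lower number here means a stronger inhibitor, a higher number a weaker inhibitor), compound 1 gives "not active" (no number reported), so no number stands against it, and it cannot be placed on a scale. Two other compounds give numbers. Compound 2 `COc1cccc(N(C)C(=O)C2CCC(c3ccc(Cl)cc3)CC2)c1`, in which the aromatic ring next to the carbonyl is replaced by a saturated ring bearing a chlorophenyl group, gives 60100 nM in this assay. Going by the values given here, compound 3 `COc1ccc(Oc2ccc(C(=O)N(C)c3cccc(OC)c3)cc2)cc1`, with methoxy in place of methyl on both outer rings, gives 9600 nM in this assay; its two values with compound 2 lie well apart, but no counted step joins them to compound 1 or to each other.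

Compound 4 `Cc1ccc(Oc2ccc(C(=O)N(C)c3cccc(C)c3)cc2)cc1` is compound 1 with one change: 4-methylphenyl in place of 2-methylphenyl on an oxygen on an aromatic ring. Among the compounds with values here, no measured pair shows the effect of moving the methyl on that ring. Within the data shown here, compound 3, the only compound with a substituent in the corresponding position, gives 9600 nM, which suggests that weak but measurable inhibition is possible in this arrangement, though compound 3 also differs on the anilide ring. For compound 4 a weak, measurable value is therefore expected, estimated at 30000 nM with a range of 8000 nM to 150000 nM, and a fair chance remains that compound 4 again shows no number.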

Compound 4, half-maximal inhibitory concentration: 26300 nM
For compound 4 the middle estimate is 1.1-fold (0.06 log units) above the measured one, within the range that was stated.
By their numbers in this assay, from the lowest: compound 3; then compound 4; then compound 2.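

Compound 1 has no number to set against compound 4, and no step can be read between them. The compounds shown leave open how large a change in inhibition goes with 2-methylphenoxy to 4-methylphenoxy on the shared core. No evidence on hand bears on this result.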